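This account rests on a few compounds, and the source may have more. Where it says the series, first, only, none or still open, it means among the compounds named here.

Compound 2 `C#CCN(C)Cc1cc2cc(O)ccc2n1C` gives, in an assay on isolated protein for inhibition of Amine oxidase [flavin-containing] A (Rattus norvegicus) (a lower number here means a stronger inhibitor, a higher number a weaker inhibitor), a value of 3.98 nM, the lowest of the two numbers measured here; its nearest neighbour, compound 1 `CC#CCN(C)Cc1cc2cc(O)ccc2n1C`, gives 5.75 nM, and the step of a 1.4-fold lower number from compound 1 to compound 2 (0.16 log units; within the scatter) lies within the scatter. The change to compound 3 `C#CCNCc1cc2cc(O)ccc2n1C` is hydrogen in place of methyl on an amine nitrogen, which reads, one bond further out, as methyl(propargyl)amino to propargylamino. For the measured compounds named here, the only step measured so far concerns the triple-bonded carbon, not the amine nitrogen, so no measured step bears on this change, and the size of the step in this assay cannot be read from the data; in the absence of any guide the expectation is set at no step beyond the scatter. Compound 3 is therefore expected to give about 6 nM, in the range 1.5 nM to 25 nM, a change of a 1.5-fold higher number from compound 2 to compound 3 (0.18 log units; within the scatter).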

Compound 3, inhibition constant: 3980 nM
The estimate for compound 3 lay 660-fold (2.82 log units) below the measured number; measured number above the stated range.
By their numbers in this assay, from the lowest: compounds 2 and 1 (each within the scatter of the next); then compound 3.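

In this assay, the amine nitrogen proves to be a far more sensitive place than the triple-bonded carbon: hydrogen in place of methyl there gives a 1000-fold higher number from compound 2 to compound 3 (3.00 log units; beyond the scatter), whereas the same exchange on the triple-bonded carbon gave only a 1.4-fold lower number from compound 1 to compound 2 (0.16 log units; within the scatter). Propargylamino in place of (but-2-yn-1-yl)(methyl)amino on the saturated chain carbon also gives a large step, a 690-fold higher number from compound 1 to compound 3 (2.84 log units; beyond the scatter). Nothing at hand accounts for this loss.

The compounds shown leave open whether a group larger than methyl on the amine nitrogen, such as ethyl or cyclopropyl, would keep the low numbers of compound 1 and compound 2. They also leave open how a but-2-yn-1-yl chain would fare with hydrogen on that nitrogen.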